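Swapping the Amine on the Acrylamide Tail

This account rests on a few compounds, and the source may have more. Where it says the series, first, only, none or still open, it means among the compounds named here.

Compound 1 `C=C(C)C(=O)Nc1cc2c(N3CCc4ccccc43)ncnc2cc1OC` gives 4830 nM in a functional assay on PC-3 cells (Homo sapiens) for antiproliferative activity, read by MTT assay, with a stated time of 72 h; a higher number here means a weaker inhibitor, a lower number a stronger inhibitor.
Compound 2 `C/C=C/C(=O)Nc1cc2c(N3CCc4ccccc43)ncnc2cc1OC` gives 8120 nM in this assay.
Compound 3 `COc1cc2ncnc(N3CCc4ccccc43)c2cc1NC(=O)/C=C/CN(C)C` gives 2190 nM in this assay.

Compound 3 stands lowest of the three: a 2.2-fold lower number from compound 1 to compound 3 (0.34 log units; beyond the scatter) and a 3.7-fold lower number from compound 2 to compound 3 (0.57 log units; beyond the scatter), both modest but beyond the scatter, while a 1.7-fold higher number from compound 1 to compound 2 (0.23 log units; within the scatter) is within it. Compound 4 `COc1cc2ncnc(N3CCc4ccccc43)c2cc1NC(=O)/C=C/CN1CCN(C)CC1` differs from compound 3 by 4-methylpiperazin-1-yl in place of dimethylamino on a saturated chain carbon bound to a double-bonded chain carbon. Among the compounds with values here, the only measured step at this place is the one from compound 2 to compound 3, where a basic amine was introduced at the chain end. Within the data shown here, no measured step exchanges one such amine for another, so a step in this assay of no more than the scatter is expected for compound 4, in either direction: a 1.1-fold lower number from compound 3 to compound 4 (0.04 log units; within the scatter). Compound 4 is estimated at 2000 nM, with a range from 900 nM to 4500 nM.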

Compound 4, half-maximal inhibitory concentration: 9180 nM
For compound 4 the middle estimate is 4.6-fold (0.66 log units) below the measured one, and the stated range ends below it.
By their numbers in this assay, from the lowest: compound 3; then compounds 1, 2 and 4 (each within the scatter of the next).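

So the identity of the amine at this chain end matters, not just the presence of one: 4-methylpiperazin-1-yl does not match dimethylamino in this assay (a 4.2-fold higher number from compound 3 to compound 4 (0.62 log units; beyond the scatter)). It also keeps none of the gain seen with dimethylamino, since the change from hydrogen to 4-methylpiperazin-1-yl stays within the scatter (a 1.1-fold higher number from compound 2 to compound 4 (0.05 log units; within the scatter)). The same holds against the 1-methylethenyl amide (a 1.9-fold higher number from compound 1 to compound 4 (0.28 log units; within the scatter)).

Nothing available explains the difference between these two amines. As far as these compounds go, whether a pyrrolidin-1-yl or morpholin-4-yl group would track with compound 3 or compound 4 remains open.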